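The source may report more compounds than this note shows. Statements on the series, on what has been measured and on what is new or still open speak of the compounds shown alone.

Compound 1, with structure `CN1CCN(Cc2cnc(Cl)s2)/C(=N\C#N)C1=O`, is measured in an assay on membranes from Head for displacement of a labelled ligand from Nicotinic acetylcholine receptor alpha 5 subunit (Musca domestica), read by scintillation counting, with a stated time of 1 h (on this read-out lower numbers stand for stronger inhibition and higher numbers for weaker inhibition), and gives 4 nM. Among the three compounds measured so far it stands at the low end of the numbers, though it is not separated from its closest neighbour: compound 3, with structure `CN1CCN(Cc2ccc(Cl)nc2)/C(=N/C#N)C1=O`, gives 6 nM in this assay, and the gap between these two falls within the usual scatter. The third compound, compound 2 with structure `O=C1/C(=N\S(=O)(=O)C(F)(F)F)NCCN1Cc1ccc(Cl)nc1`, gives 593 nM in this assay, a number well beyond the scatter above that of compound 1.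

The compound that follows from compound 1 is compound 4, with structure `CN1CCN(CC2CCOC2)/C(=N\C#N)C1=O`. Its difference from compound 1 is oxolan-3-yl in place of 2-chloro-1,3-thiazol-5-yl on a saturated chain carbon bound to an amine nitrogen in a ring. Going by the values given here, no step between two measured compounds covers this exchange, so nothing measured here tells its size directly. The expectation for this assay is nevertheless a sizeable step upward, that is toward weaker inhibition, and compound 4 is estimated at 400 nM, with a range from 80 nM to 3000 nM, which as a step means a 100-fold higher number from compound 1 to compound 4 (2.00 log units; beyond the scatter).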

Compound 4, inhibition constant: 517 nM
Compound 4: the middle estimate sits 1.3-fold (0.11 log units) below what was measured; the range from low to high includes it.
By their numbers in this assay, from the lowest: compounds 1 and 3 (each within the scatter of the next); then compounds 4 and 2 (each within the scatter of the next).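

Going by these compounds alone, putting oxolan-3-yl in place of 2-chloro-1,3-thiazol-5-yl on a saturated chain carbon bound to an amine nitrogen in a ring gives a 130-fold higher number from compound 1 to compound 4 (2.11 log units; beyond the scatter) in this assay and provides the first direct reading of an exchange at this position. A five-membered ring remains in this place, yet the number changes by a large step once the aromatic ring with 2 hetero atoms gives way to a non-aromatic ring with 1 hetero atom, so the presence of a five-membered ring alone does not preserve the low number of compound 1. No measurement shown here identifies which feature of the exchange accounts for the step.

The compounds shown leave open whether the step follows the loss of the aromatic ring, the sulfur and ring nitrogen, or the chlorine. A furan-3-yl or a 5-chlorothiophen-2-yl group on the same carbon would help separate these parts of the exchange.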